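Isopropyl for Methyl on the 4-Methylpiperidin-1-yl Group

A few compounds are considered here, and "the series" means these few. Any claim that something is new, unique, unknown or untested is made for them only; others in the source may bear on it.

Measured compounds:
compound 1, `COc1ccc2[nH]c(C(=O)N3CC(=O)N(Cc4ccccc4)[C@@H](CN4CCC(C)CC4)C3)cc2c1`, 93100 nM in a physicochemical assay for solubility, read by spectrophotometry, in phosphate buffer, with a stated time of 2 h, at pH 7.4; on this read-out higher numbers stand for higher solubility and lower numbers for lower solubility
compound 2, `COc1ccc2[nH]c(C(=O)N3CC(=O)N(Cc4ccccc4)[C@@H](CN4CCN(S(=O)(=O)c5ccccc5)CC4)C3)cc2c1`, 16900 nM

Compound 1 gives the higher of the two numbers in this assay. Its nearest neighbour is compound 2, whose number is lower by a gap that lies beyond the usual scatter of this kind of measurement. Among the compounds with values here, no pair of measured compounds differs in just one place, so there is no single measured step to lean on.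

Compound 3 is `COc1ccc2[nH]c(C(=O)N3CC(=O)N(Cc4ccccc4)[C@@H](CN4CCC(C(C)C)CC4)C3)cc2c1`. It differs from compound 1 in one place only: isopropyl in place of methyl on a saturated ring carbon. The 4-methylpiperidin-1-yl group of compound 1 becomes a 4-isopropylpiperidin-1-yl group, and the rest of the shared core is kept.

Within the data shown here, nothing among the measured compounds shows what this change does in this assay. The step from compound 1 to compound 3 is expected to be a modest decrease, a 2.1-fold lower number from compound 1 to compound 3 (0.32 log units; beyond the scatter), though one that may not clear the scatter. Compound 3 is therefore estimated at 45000 nM, within a range from 15000 nM to 95000 nM.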

Compound 3, solubility: 12000 nM
Beside the measured number, compound 3's estimate is 3.8-fold (0.57 log units) above it, outside the stated range (below it).
By their numbers in this assay, from the lowest: compounds 3 and 2 (each within the scatter of the next); then compound 1.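

In this assay, within the data shown here, the exchange of methyl for isopropyl on a saturated ring carbon, three ring bonds from the ring nitrogen, gives the first single-place step at this position (a 7.8-fold lower number from compound 1 to compound 3 (0.89 log units; beyond the scatter)). This shows that the read-out responds to what stands on this carbon, since the 4-methylpiperidin-1-yl group of compound 1 becoming the 4-isopropylpiperidin-1-yl group of compound 3 moves the number beyond the scatter, although the change adds no hydrogen-bond donor, hydrogen-bond acceptor, ring or net charge. Nothing shown gives a reason for the direction or size of this step.

With only methyl and isopropyl shown at this position, one step cannot tell whether the number would keep falling with a longer chain such as n-butyl or a larger group such as tert-butyl. It also leaves open what a hydroxyl, a primary amine or a carboxylic acid on the same ring carbon would do in this read-out, and whether the step would hold on a core carrying a different group in place of the benzyl.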